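The source may report more compounds than this note shows. Statements on the series, on what has been measured and on what is new or still open speak of the compounds shown alone.

Compound 1 `COc1cc2c(cc1OC)CN(S(=O)(=O)c1ccc(-n3cc(COc4ccc(C=O)cc4)nn3)cc1)CC2` is a limit of the assay: in an ADME assay on Vero cells (Chlorocebus sabaeus) for cytotoxicity, with a stated time of 4 days (on this read-out lower numbers stand for stronger inhibition and higher numbers for weaker inhibition), compound 1 gives > 50 ug/mL.
Compound 2 `COc1cc2c(cc1OC)CN(S(=O)(=O)c1ccc(-n3cc(COc4ccc5ccccc5c4)nn3)cc1)CC2` is also a limit; compound 2 gives > 50 ug/mL.
Compound 3 `O=S(=O)(c1ccc(-n2cc(COc3ccccc3)nn2)cc1)N1CCc2ccccc2C1` is a limit too; compound 3 gives > 50 ug/mL.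

Compound 1 therefore stands only at a limit, with no number of its own. Compound 4 `COc1cc2c(cc1OC)CN(S(=O)(=O)c1ccc(-n3cc(COc4cc(C=O)ccc4OC)nn3)cc1)CC2` differs from it in one place: 5-formyl-2-methoxyphenyl in place of 4-formylphenyl on an oxygen on a saturated carbon. Among the measured compounds shown here, the one measured change of the same kind, a step that the two limits leave unreadable from compound 1 to compound 2, cannot be sized, because of the limit of > 50 ug/mL in this assay, at which 3 of the 3 values shown sit. No measured step is readable, so no direction can be drawn from the numbers shown. Compound 4 is estimated at 60 ug/mL, expected between 30 ug/mL and 120 ug/mL, most likely reported again as a limit. The expected step is a step that the limit leaves unreadable from compound 1 to compound 4, within scatter.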

Compound 4, half-maximal inhibitory concentration: > 50 ug/mL
Compound 4 was reported as a limit; the forecaster's own chance of this, stated with the estimate: 85%; the middle value does not contradict the limit.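

Compound 4 adds no readable step against compound 1 or compound 2, because all of these results are limits: the limit of > 50 ug/mL in this assay, at which 4 of the 4 values shown sit.

The compounds shown leave open how strongly each inhibits in this assay, and whether changing the group on the oxygen matters at all.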